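Aryl swap at the pyridine core: compound 2 to compound 4

The source may report more compounds than this note shows. Statements on the series, on what has been measured and on what is new or still open speak of the compounds shown alone.

Measured so far:
- compound 1 `COc1nc(-c2cc3ccccc3o2)cc(-c2ccc(Br)cc2)c1C#N`: 298000 nM
- compound 2 `CCOc1nc(-c2cc3ccccc3o2)cc(-c2ccc(Br)cc2)c1C#N`: 227000 nM
- compound 3 `COc1nc(-c2cc3ccccc3o2)cc(-c2ccc(N(C)C)cc2)c1C#N`: 278000 nM

All three were tested in a functional assay on aorta (strain Wistar) for inhibition, with Thoracic aorta (Rattus norvegicus) as the target; a lower number here means a stronger inhibitor, a higher number a weaker inhibitor. Compound 2 gives the lowest of the three numbers, but its gaps to compound 3 and to compound 1 both sit inside the usual scatter, so no order among the three can be claimed. The step of a 1.3-fold lower number from compound 1 to compound 2 (0.12 log units; within the scatter) and the step of a 1.1-fold lower number from compound 1 to compound 3 (0.03 log units; within the scatter) are likewise both inside the scatter.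

Compound 4 `CCOc1nc(-c2cc3ccccc3o2)cc(-c2cn(C)c3ccccc23)c1C#N` follows from compound 2 by one change: 1-methyl-1H-indol-3-yl in place of 4-bromophenyl on an aromatic carbon. Going by the values given here, of the measured steps, only the step from compound 1 to compound 3 touches the same six-membered aromatic ring of carbon only, and it was flat; the step from compound 1 to compound 2 concerns the ethoxy side and was flat too. Nothing measured yet tells what replacing the whole ring by 1-methyl-1H-indol-3-yl does. Among the compounds with values here, the expectation for compound 4 is therefore a step of a 1.0-fold lower number from compound 2 to compound 4 (0.01 log units; within the scatter) that stays within the scatter, with a wide range because this change has no precedent. Compound 4 is estimated at 220000 nM, between 70000 nM and 700000 nM.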

Compound 4, half-maximal inhibitory concentration: 327000 nM
Beside the measured number, compound 4's estimate is 1.5-fold (0.17 log units) below it, and the stated range covers the measured number.
By their numbers in this assay, from the lowest: compounds 2, 3, 1 and 4 (each within the scatter of the next).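

Placing 1-methyl-1H-indol-3-yl in place of 4-bromophenyl, on the aromatic carbon opposite the ring nitrogen, gives in this assay a 1.4-fold higher number from compound 2 to compound 4 (0.16 log units; within the scatter). The earlier step at this position changed only the group on the six-membered aromatic ring of carbon only, whereas this one replaces the whole aryl group, with a five-membered aromatic ring and a hydrogen-bond acceptor entering, and still gives no readable shift. No supporting data bear on this result.

Open, on these data alone, is whether anything at this position moves the number beyond the scatter, for example a carboxylic acid or a primary amine on the aryl group. Also open, as far as these compounds go, is what a change to the nitrile or the 1-benzofuran-2-yl group would do, as both stay the same in all four compounds, and whether a chain longer than ethoxy departs from the flat picture.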